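Methoxy Addition on the Benzyl Ring: Outlook for Compound 4

The source may hold more compounds than are shown below. What is called first, only, known or untested is meant among the compounds shown, and "the series" means these compounds.

Compound 1 `COc1cc(Cn2cc(CNC(=O)c3cn(-c4ccccc4)nc3-c3ccccc3)nn2)cc(OC)c1` carries a 3,5-dimethoxybenzyl group on the shared core; in a functional assay on MCF7 cells (Homo sapiens) for antiproliferative activity, read by sulforhodamine B assay, with a stated time of 48 h (on this read-out higher numbers stand for weaker inhibition of growth and lower numbers for stronger inhibition of growth), compound 1 gives 2400 nM. Compound 2 `COc1cc(Cn2cc(CNC(=O)c3cn(-c4ccccc4)nc3-c3ccccc3)nn2)cc(OC)c1OC` differs from it by methoxy in place of hydrogen on an aromatic carbon. In this assay compound 2 reaches only > 100000 nM, which is a limit of the assay and not a number. The step of an at least 41-fold higher number from compound 1 to compound 2 (1.61 log units; beyond the scatter) is accordingly known only as a lower bound, resting on (the limit of > 100000 nM in this assay, at which 1 of the 3 values shown sits).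

Compound 3 `COc1ccc(Cn2cc(CNC(=O)c3cn(-c4ccccc4)nc3-c3ccc(Cl)cc3)nn2)cc1` has a different core; the difference between the cores of compound 1 and compound 3 is not broken down here. In this assay compound 3 gives 8000 nM, a higher number than compound 1.

Compound 4 `COc1ccc(Cn2cc(CNC(=O)c3cn(-c4ccccc4)nc3-c3ccc(Cl)cc3)nn2)cc1OC` has not yet been measured. It differs from compound 3 by methoxy in place of hydrogen on an aromatic carbon. This is the same kind of change as that from compound 1 to compound 2, not the same change: in compound 2 the entering methoxy sits ortho to two methoxy groups and para to a large group, in compound 4 it sits ortho to a methoxy group and meta to a large group. With a single precedent, and that one differing in its surroundings, the expectation is a step of a 7.5-fold higher number from compound 3 to compound 4 (0.88 log units; beyond the scatter) towards a higher number, resting on the step of an at least 41-fold higher number from compound 1 to compound 2 (1.61 log units; beyond the scatter). On that basis compound 4 is estimated at 60000 nM in this assay, with an expected range from 15000 nM to 300000 nM, and a real chance that only a limit is returned.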

Compound 4, concentration for 50% growth inhibition: > 100000 nM
Compound 4: no number, only a limit; the forecaster's own chance of this, stated with the estimate: 40%; at least 1.6-fold (0.22 log units) between middle value and limit.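

In this assay compound 4 gives > 100000 nM, which is a limit of the assay and not a number. Going from the 4-methoxybenzyl to the 3,4-dimethoxybenzyl group gives an at least 12-fold higher number from compound 3 to compound 4 (1.09 log units; beyond the scatter), so on both cores shown, methoxy in place of hydrogen on an aromatic carbon of the benzyl ring moves the read-out towards weaker inhibition of growth, and the two steps compare as follows: the same change on two cores in this assay, an at least 41-fold higher number (1.61 log units; beyond the scatter) from compound 1 to compound 2 and an at least 12-fold higher number (1.09 log units; beyond the scatter) from compound 3 to compound 4; the limit leaves it open whether they differ. This pair of cases does not show the true size of either step, nor whether the core changes that size, and the entering methoxy also sits in different surroundings in the two cases, so the reading cannot go further because of how many values end at the limit: the limit of > 100000 nM in this assay, at which 2 of the 4 values shown sit.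

The compounds shown leave open whether a hydroxy group, a fluorine atom or an ethoxy group in the place of the entering methoxy would give a measurable number in this assay on either core. Also open, on these data alone, is how the 3,4-dimethoxybenzyl group reads on the core of compound 1, and how the 3,5-dimethoxybenzyl group reads on the core of compound 3, which would separate the effect of the core from that of the substitution pattern.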